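A few compounds are considered here, and "the series" means these few. Any claim that something is new, unique, unknown or untested is made for them only; others in the source may bear on it.

The series shares one core; compound 1 `COc1ccc(-c2cc(-c3cc4ccccc4n3C)no2)cc1` carries a methoxy on its outer ring, compound 2 `COc1cccc(-c2cc(-c3cc4ccccc4n3C)no2)c1` carries the methoxy at a different place on that ring, and compound 3 `COc1ccc(-c2cc(-c3c(Cl)c4ccccc4n3C)no2)cc1` adds a chloro to the core of compound 1. In a functional assay on Calu-3 cells (Homo sapiens) for cytotoxicity, read by WST assay, with a stated time of 72 h (on this read-out higher numbers stand for weaker inhibition and lower numbers for stronger inhibition), compound 1 reports only a limit, > 100000 nM. Compound 2 gives 17300 nM and compound 3 gives 60900 nM. Among the two numbers actually read, compound 3 stands highest, with compound 2 the nearest below it by a gap beyond the scatter. Within the data shown here, the only measured step, an at least 1.6-fold lower number from compound 1 to compound 3 (0.21 log units; that floor lies within the scatter), sets a floor that sits within the scatter, and it rests on the limit of > 100000 nM in this assay, at which 1 of the 3 values shown sits, of compound 1 rather than on a read number.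

Compound 4 `Cn1c(-c2cc(-c3ccc(C(F)(F)F)cc3)on2)c(Cl)c2ccccc21` differs from compound 3 by trifluoromethyl in place of methoxy on an aromatic carbon. Among the measured compounds shown here, no measured step touches the group on that ring; the pair compound 1 and compound 2 shows only that the methoxy at one place reads as a limit and at the other as a number. The chloro step gives no guide to this change either. The expected step, a 1.1-fold lower number from compound 3 to compound 4 (0.04 log units; within the scatter), therefore carries no direction beyond the scatter. Compound 4 is estimated at 55000 nM in this assay, between 15000 nM and 150000 nM.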

Compound 4, half-maximal inhibitory concentration: > 100000 nM
Compound 4: only a limit was reported; the forecaster's own chance of this, stated with the estimate: 30%; middle value at least 1.8-fold (0.25 log units) away from the limit.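

In this assay, trifluoromethyl in place of methoxy on the aromatic carbon para to a large group gives an at least 1.6-fold higher number from compound 3 to compound 4 (0.21 log units; that floor lies within the scatter). Among these compounds, this is the first change to the group at this position while the rest of compound 3 stays fixed, and it brings no lower number; no direction beyond the scatter can be claimed, and the true size of the step stays unknown since only its floor is available. Compound 4, like compound 1, reports a limit and not a number, so the chloro does not keep the series on readable values once methoxy leaves: the limit of > 100000 nM in this assay, at which 2 of the 4 values shown sit.

Still open, on these data alone, is what an amine or a carboxylic acid at this position would read in this assay, and whether such a group would bring the number down or leave it at the limit. Also open, as far as these compounds go, is whether trifluoromethyl on the core of compound 1, without the chloro, gives a number or a limit, and whether trifluoromethyl at the place held by the methoxy of compound 2 reads differently.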